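The source may hold more compounds than are shown below. What is called first, only, known or untested is meant among the compounds shown, and "the series" means these compounds.

Three compounds share one saturated core and differ only in what hangs from the amine nitrogen on that core. Compound 1 `N#Cc1ccc(CN[C@@H]2CN[C@H](C(=O)N3CCSC3)C2)cc1` carries the nitrile-bearing benzyl group on an unsubstituted nitrogen, and in an assay on a cell-free system (plasma) for inhibition of Dipeptidyl peptidase 4 (Rattus norvegicus), read by fluorescence (on this read-out lower numbers stand for stronger inhibition and higher numbers for weaker inhibition), compound 1 gives 34.3 nM. Compound 2 `N#Cc1ccc(C(=O)N[C@@H]2CN[C@H](C(=O)N3CCSC3)C2)cc1` replaces that benzyl linkage with an amide, and in this assay compound 2 gives 34.1 nM. Among the compounds with values here, compound 3 `CN(Cc1ccc(C#N)cc1)[C@@H]1CN[C@H](C(=O)N2CCSC2)C1` keeps the benzyl group and adds a methyl to the nitrogen, and in this assay compound 3 gives 13.6 nM; this is the lowest of the three numbers, and the only measured step, a 2.5-fold lower number from compound 1 to compound 3 (0.40 log units; beyond the scatter), is the one that leads to it.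

Compound 4 `CCCCN(Cc1ccc(C#N)cc1)[C@@H]1CN[C@H](C(=O)N2CCSC2)C1` differs from compound 3 by propyl in place of hydrogen on a saturated chain carbon bound to an amine nitrogen. Within the data shown here, only one measured step touches this nitrogen, and it concerns the first alkyl group rather than its lengthening, so it bears on the new step only loosely. Because a 2.5-fold lower number from compound 1 to compound 3 (0.40 log units; beyond the scatter) was modest, the expectation for a further extension is a step of similar or smaller size in either direction, and the estimate a 1.5-fold higher number from compound 3 to compound 4 (0.17 log units; within the scatter) is a number for compound 4 within the scatter of compound 3. In this assay compound 4 is therefore estimated at 20 nM, between 7 nM and 60 nM.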

Compound 4, half-maximal inhibitory concentration: 5 nM
For compound 4 the middle estimate is 4.0-fold (0.60 log units) above the measured one; the whole stated range lies above it.
By their numbers in this assay, from the lowest: compound 4; then compound 3; then compounds 2 and 1 (each within the scatter of the next).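

In this assay, lengthening the methyl on the amine nitrogen to butyl carries the number further in the same direction as the first alkyl step (a 2.7-fold lower number from compound 3 to compound 4 (0.43 log units; beyond the scatter)), so the trend does not stop at methyl. Measured from the unsubstituted nitrogen, the whole change to butyl is larger (a 6.9-fold lower number from compound 1 to compound 4 (0.84 log units; beyond the scatter)), and among the compounds that keep the benzyl linkage the numbers fall in the order hydrogen, methyl, butyl, with none of them going against that order; compound 2, with its amide linkage, stands outside this series. The position therefore tolerates a chain of this length with a gain at each measured step, but nothing shown here bears on why the number falls.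

On these data alone, whether the fall continues with a longer chain such as hexyl, or holds for a branched group such as isopropyl or a ring-bearing group such as cyclohexylmethyl, stays open. As far as these compounds go, it is also open whether a methyl or butyl on the amide nitrogen of compound 2 would move the number as it does on the amine nitrogen.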